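Replacing the tetrazole amide with a carboxypropyl chain

The source may report more compounds than this note shows. Statements on the series, on what has been measured and on what is new or still open speak of the compounds shown alone.

The shared core of compound 3 `O=C(Nc1nnn[nH]1)c1cc(=O)c2ccccc2o1` carries an amide whose nitrogen bears a 1H-tetrazol-5-yl group. In a functional assay on cells (Mast cell, Rattus norvegicus) for inhibition, with a stated time of 15 min (on this read-out higher numbers stand for an effect only at larger amounts of compound and lower numbers for an effect already at smaller amounts), compound 3 gives 0.08 ug/mL, the lowest of the two numbers shown. Its nearest neighbour is compound 2 `O=C(Nc1nc[nH]n1)c1cc(=O)c2ccccc2o1`, which in this assay gives 5 ug/mL; the step of a 63-fold lower number from compound 2 to compound 3 (1.80 log units; beyond the scatter) is large. Compound 1 `O=C(O)CCCCCNC(=O)c1cc(=O)c2ccccc2o1`, with a 5-carboxypentyl chain on the amide nitrogen, reaches only a limit in this assay, > 18 ug/mL, so no number is known for it (the limit of > 18 ug/mL in this assay, at which 1 of the 3 values shown sits).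

Compound 4 `O=C(O)CCCNC(=O)c1cc(=O)c2ccccc2o1` has not yet been measured. Compared with compound 3 it differs as follows: 3-carboxypropyl in place of 1H-tetrazol-5-yl on an amide-type nitrogen. Among the measured compounds shown here, no measured step joins a tetrazole amide directly to a carboxyalkyl amide, so the bearing evidence is indirect. The step from compound 2 to compound 3 shows that the choice of the group on the amide nitrogen can move the number far beyond the scatter, and compound 1 shows that a carboxyalkyl chain at that position gave no number within the range of this assay. A large rise is therefore expected for compound 4, a 250-fold higher number from compound 3 to compound 4 (2.40 log units; beyond the scatter), and its value in this assay is estimated at 20 ug/mL, in the range 4 ug/mL to 100 ug/mL, with a fair chance that only a limit is obtained.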

Compound 4, concentration for half-maximal effect: > 18 ug/mL
Compound 4 ended at the assay's limit; the forecaster's own chance of this, stated with the estimate: 60%; the middle value does not contradict the limit.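

Among the compounds shown here, putting 3-carboxypropyl on the amide-type nitrogen gives the first direct comparison between this chain and the ring groups in this assay: replacing 1H-tetrazol-5-yl gives an at least 220-fold higher number from compound 3 to compound 4 (2.35 log units; beyond the scatter), and replacing 1H-1,2,4-triazol-3-yl gives an at least 3.6-fold higher number from compound 2 to compound 4 (0.55 log units; beyond the scatter). Both steps rest on a limit for compound 4, so each gives only a lower bound on the size of the change, yet both lie beyond the scatter. Compound 1 and compound 4 carry chains of different length and stand at the same limit, so the step between them cannot be read and shows no effect of chain length: the limit of > 18 ug/mL in this assay, at which 2 of the 4 values shown sit.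

The compounds shown leave open whether the loss of the ring itself or the terminal carboxylic acid accounts for these steps, a question that a 1H-tetrazol-5-yl group or a primary amine at the end of the same chain would address. They also leave open how far past the limit compound 4 lies, and whether a carboxymethyl chain, shorter than either chain here, would give a number in this assay.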